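Tail variation on the shared core: bromo to carboxy

A few compounds are considered here, and "the series" means these few. Any claim that something is new, unique, unknown or untested is made for them only; others in the source may bear on it.

Three compounds share the core of compound 1 `O=c1c(-c2ccc(O)cc2)coc2cc(OCCCCCCBr)ccc12` and differ only in the chain on the aromatic oxygen. In a functional assay on mitochondria (Cricetulus griseus) for inhibition of Monoamine oxidase (Homo sapiens), tested at 3 uM (a higher number here means a stronger effect of the compound at the concentration tested, a lower number a weaker effect), compound 1 gives 88.5%. Compound 2 `C=CCOc1ccc2c(=O)c(-c3ccc(O)cc3)coc2c1` gives 89.3% and compound 3 `O=c1c(-c2ccc(O)cc2)coc2cc(OCC(O)CO)ccc12` gives 85%; compound 1 lies within the scatter of both, so no order among the three can be read from the numbers.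

Compound 4 `O=C(O)CCCCCCOc1ccc2c(=O)c(-c3ccc(O)cc3)coc2c1` is not yet measured. Against compound 1 it shows (carboxy in place of bromo on a saturated chain carbon, six bonds along the chain from an oxygen on an aromatic ring).

Among the compounds with values here, the steps that bear on this change are those that also alter the chain end: a number 0.8 percentage points higher from compound 1 to compound 2 (within the scatter) and a number 3.5 percentage points lower from compound 1 to compound 3 (within the scatter), with a number 4.3 percentage points lower from compound 2 to compound 3 (within the scatter) between the two other chain ends. All three are within the scatter, and the chain end has so far not moved this assay.

Compound 4 is therefore expected at 86%, with a range from 72% to 95%; this estimate means a number 2.5 percentage points lower from compound 1 to compound 4 (within the scatter), a step expected to stay within the scatter.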

Compound 4, a percentage reported as inhibition, at one concentration (the size of the read-out at that concentration, not a potency): 87.4%
For compound 4 the middle estimate is 1.4 percentage points below the measured one, and the stated range covers the measured number.
By their numbers in this assay, from the lowest: compounds 3, 4, 1 and 2 (each within the scatter of the next).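

Carboxy in place of bromo, six bonds along the chain from an oxygen on an aromatic ring, gives a number 1.1 percentage points lower from compound 1 to compound 4 (within the scatter) in this assay, so this exchange, which adds a hydrogen-bond donor and a hydrogen-bond acceptor to the chain end, does not separate the two compounds. The other two comparisons agree, with a number 2.4 percentage points higher from compound 3 to compound 4 (within the scatter) and a number 1.9 percentage points lower from compound 2 to compound 4 (within the scatter), so all four chain ends now lie within the scatter of one another. No measurement at hand accounts for this flat result.

From the compounds shown here alone, whether an amine at the chain end or a longer chain would move this assay remains open. Because each compound was read at a single concentration, any differences in potency among these four compounds also remain open.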